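Compound 1 to compound 3: an expected stability step

This account rests on a few compounds, and the source may have more. Where it says the series, first, only, none or still open, it means among the compounds named here.

Compound 1 `CCCC(=O)NCCCCCC(=O)N[C@H](C(=O)N1C[C@H](O)C[C@H]1C(=O)NCc1ccc(-c2scnc2C)cc1)C(C)(C)C` stands at 83% in an ADME assay on a cell-free system (plasma, Homo sapiens) for metabolic stability, with a stated time of 90 min; on this read-out lower numbers stand for a less stable compound and higher numbers for a more stable compound. Compound 2 `CCCCOc1ccc(-c2ccc(C(=O)NCCCCCC(=O)N[C@H](C(=O)N3C[C@H](O)C[C@H]3C(=O)NCc3ccc(-c4scnc4C)cc3)C(C)(C)C)cc2)cc1` gives 83% in this assay, level with compound 1 within the scatter, although the two differ in the group carried on the shared core. Within the data shown here, these two values are the only measurements available, and they form no step that bears on the next change.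

Compound 3 `COCC(=O)OCCCCCC(=O)N[C@H](C(=O)N1C[C@H](O)C[C@H]1C(=O)NCc1ccc(-c2scnc2C)cc1)C(C)(C)C` differs from compound 1 by ((methoxymethyl)carbonyl)oxy in place of (propylcarbonyl)amino on a saturated chain carbon, five bonds along the chain from a carbonyl carbon. Among the measured compounds shown here, the incoming ((methoxymethyl)carbonyl)oxy group appears in no measured compound, so the data give no direct guide to its effect. The expectation is therefore a judgement about the structural change, not a trend read from the series, and it carries a wide range. A fall beyond the scatter is expected in this assay. The expected size is given by the estimated step of a number 43 percentage points lower from compound 1 to compound 3 (beyond the scatter), a large drop rather than a marginal one. For compound 3 the estimated value is 40%, with an expected range of 5% to 80%.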

Compound 3, percent of the compound remaining: 1%
Estimate against measurement, compound 3: 39 percentage points above; the whole stated range lies above it.
By their numbers in this assay, from the lowest: compound 3; then compounds 1 and 2 (each within the scatter of the next).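

In this assay, ((methoxymethyl)carbonyl)oxy in place of (propylcarbonyl)amino on a saturated chain carbon, five bonds along the chain from a carbonyl carbon, gives a number 82 percentage points lower from compound 1 to compound 3 (beyond the scatter), so the read-out is not indifferent to the group at this position. The earlier pair showed no such sensitivity: compound 1 at 83% and compound 2 at 83% stand level within the scatter, and both keep the amide nitrogen on this chain carbon, which compound 3 lacks. The step also comes with no change in the heavy-atom count of the group, which stays at 6, while the count of hydrogen-bond donors goes from 1 to 0 and that of acceptors from 1 to 3.

Nothing available explains why the value falls so far. The linking atom and the methoxymethyl end change together, so the step cannot be assigned to either one; the (propylcarbonyl)oxy and ((methoxymethyl)carbonyl)amino groups would separate the two, and a carbamate or a longer chain at the same place would show how far the effect extends.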